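Naphthalenyl replacing phenyl on the anilide of compound 1

The source may report more compounds than this note shows. Statements on the series, on what has been measured and on what is new or still open speak of the compounds shown alone.

Measured so far:
Compound 1 `C[C@H](NC(=O)C(=O)Nc1ccccc1)C(=O)N[C@@H](CC(=O)O)C(=O)COc1c(F)c(F)cc(F)c1F` — 670 nM
Compound 2 `C[C@H](NC(=O)C(=O)Nc1ccccc1C(F)(F)F)C(=O)N[C@@H](CC(=O)O)C(=O)COc1c(F)c(F)cc(F)c1F` — 61 nM
Compound 3 `C[C@H](NC(=O)C(=O)Nc1ccccc1-c1ccccc1)C(=O)N[C@@H](CC(=O)O)C(=O)COC(=O)c1c(F)c(F)cc(F)c1F` — 130 nM

In a functional assay on Jurkat cells (Homo sapiens) for inhibition (a higher number here means a weaker inhibitor, a lower number a stronger inhibitor), compound 1 gives 670 nM, the highest number of the three. Compound 2 stands nearest with 61 nM, and compound 3, which also carries a different linkage to its fluorinated ring, gives 130 nM. Among the measured compounds shown here, only one single-point step is available: an 11-fold lower number from compound 1 to compound 2 (1.04 log units; beyond the scatter), a large improvement for adding a trifluoromethyl to the anilide ring.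

Compound 4 `C[C@H](NC(=O)C(=O)Nc1cccc2ccccc12)C(=O)N[C@@H](CC(=O)O)C(=O)COc1c(F)c(F)cc(F)c1F` is the next compound to be tested. It differs from compound 1 in one place: naphthalen-1-yl in place of phenyl on an amide-type nitrogen. This is again a change that enlarges the anilide aromatic part, so the step from compound 1 to compound 2 in this assay is the closest guide, while compound 3 with its biphenyl only shows that a larger aromatic group there is compatible with a lower number. For the measured compounds named here, since no compound tests the naphthalenyl itself, an improvement smaller than the trifluoromethyl step is expected.

For compound 4 in this assay the estimate is 200 nM, within 70 nM to 700 nM, that is an expected step of a 3.4-fold lower number from compound 1 to compound 4 (0.53 log units; beyond the scatter).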

Compound 4, half-maximal inhibitory concentration: 86 nM
The estimate for compound 4 lay 2.3-fold (0.37 log units) above the measured number; measured number inside the range.
By their numbers in this assay, from the lowest: compounds 2, 4 and 3 (each within the scatter of the next, the first and the last beyond it); then compound 1.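

In this assay, naphthalen-1-yl in place of phenyl on the amide-type nitrogen gives a 7.8-fold lower number from compound 1 to compound 4 (0.89 log units; beyond the scatter) and so shows that the lower number at this place does not depend on a trifluoromethyl group: an unsubstituted carbon-only group of two six-membered aromatic rings also achieves it. Set directly against 2-(trifluoromethyl)phenyl, the same group gives a 1.4-fold higher number from compound 2 to compound 4 (0.15 log units; within the scatter) and cannot be told apart from it in this assay, so two different replacements for phenyl end up at a level that these data do not separate. Nothing available explains why either replacement lowers the number.

Still open, on these data alone, is whether naphthalen-2-yl, or a phenyl ring carrying a methoxy group, an amine or a carboxylic acid, would hold the number at this level on the same nitrogen. The compounds shown also leave open whether naphthalen-1-yl would have the same effect with the carbonyl-containing linkage to the fluorinated ring seen in compound 3, since no pair isolates that change.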